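From isopropyl to oxan-4-yl in compound 4

This account rests on a few compounds, and the source may have more. Where it says the series, first, only, none or still open, it means among the compounds named here.

Compound 1 `Cc1cc(NC(=O)C2CCCCC2)nn1Cc1cc(Cl)ccc1OCC(C)C` has the limit > 3.7 as its value
Compound 2 `Cc1cc(NC(=O)C2CCCC2)nn1Cc1cc(Cl)ccc1OCC(C)C` has the limit > 3.7 as its value
Compound 3 `Cc1cc(NC(=O)OC(C)C)nn1Cc1cc(Cl)ccc1OCC(C)C` has the limit > 3.7 as its value

These three readings come from a physicochemical assay for lipophilicity, at pH 7.4 (a higher number here means a more lipophilic compound, a lower number a more polar compound), and each is a limit, not a number. Compound 3 stands at the limit of > 3.7 in this assay, at which 3 of the 3 values shown sit, and so has no number of its own.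

Going by the values given here, compound 4 `Cc1cc(NC(=O)OC2CCOCC2)nn1Cc1cc(Cl)ccc1OCC(C)C` has not been measured, and its one change from compound 3 (oxan-4-yl in place of isopropyl on an oxygen next to a carbonyl group) puts oxan-4-yl in place of isopropyl on an oxygen next to a carbonyl group. The measured steps offer a step that the two limits leave unreadable from compound 1 to compound 3 and a step that the two limits leave unreadable from compound 2 to compound 3 and also a step that the two limits leave unreadable from compound 1 to compound 2 and so give no size to carry over. For compound 3 the limit > 3.7 is the only starting point, and the hydrogen-bond acceptor entering with oxan-4-yl leads to an expected fall of moderate size. The step expected is a number at least 0.10 log units lower from compound 3 to compound 4 (that floor lies within the scatter) and it is an estimate only. In this assay compound 4 is estimated at 3.6 with an expected range of 3 to 4.2 and it may again read as a limit.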

Compound 4, distribution coefficient: 3.4
The estimate for compound 4 lay 0.20 log units above the measured number, within the range that was stated.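

In this assay, oxan-4-yl in place of isopropyl on an oxygen next to a carbonyl group gives a number at least 0.30 log units lower from compound 3 to compound 4 (that floor lies within the scatter), whereas the steps among compound 1, compound 2 and compound 3 cannot be read. The change also connects to the other two compounds: (oxan-4-yl)oxy in place of cyclopentyl on a carbonyl carbon gives a number at least 0.30 log units lower from compound 2 to compound 4 (that floor lies within the scatter), and (oxan-4-yl)oxy in place of cyclohexyl on a carbonyl carbon gives a number at least 0.30 log units lower from compound 1 to compound 4 (that floor lies within the scatter). Going by these compounds alone, compound 4 is thus the only compound here with a number, and the others remain at a limit: the limit of > 3.7 in this assay, at which 3 of the 4 values shown sit.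

As far as these compounds go, how large the step truly is stays open, as compound 3 has only a limit. Also open, from the compounds shown here alone, is how a piperidin-4-yl group or a 2-methoxyethyl chain would read on an oxygen next to a carbonyl group.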